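Extending the Pentyl Chain with a Terminal Phenyl

A few compounds are considered here, and "the series" means these few. Any claim that something is new, unique, unknown or untested is made for them only; others in the source may bear on it.

Of the compounds shown here, three have been measured in an assay on HEK293 cells for agonist activity at Toll-like receptor 8 (Homo sapiens), read by spectrophotometry; on this read-out lower numbers stand for an effect already at smaller amounts and higher numbers for an effect only at larger amounts of compound. Compound 3 `CCCCCc1c(C)nc(N)nc1NCCCC` gives 1220 nM and stands second highest of the three numbers. Compound 1 `CCCCNc1nc(N)nc(C)c1CCCn1c(C)nc2ccccc21`, whose side chain ends in an aromatic group, gives 366 nM, a lower number than compound 3 and beyond the scatter. Compound 2 `C#Cc1c(C)nc(N)nc1NCCCC` gives 4900 nM, the highest of the three.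

Compound 4 `CCCCNc1nc(N)nc(C)c1CCCCCc1ccccc1` has not yet been measured. It differs from compound 3 in one place: phenyl in place of hydrogen on a saturated chain carbon, five bonds along the chain from an aromatic carbon. Among the measured compounds shown here, only one measured step changes a single place, a 4.0-fold lower number from compound 2 to compound 3 (0.60 log units; beyond the scatter), and it bears on this change indirectly: a longer saturated chain on the same aromatic carbon went with a lower number. Compound 1, at 366 nM, also shows that a chain ending in an aromatic group goes with a lower number than the plain pentyl chain of compound 3. For the measured compounds named here, since no measured pair shows this exact change, a modest step toward a lower number is expected, with a wide range.

Compound 4 is therefore estimated at 500 nM, between 150 nM and 1500 nM. The expected step is a 2.4-fold lower number from compound 3 to compound 4 (0.39 log units; beyond the scatter) in this assay.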

Compound 4, half-maximal effective concentration: 830 nM
Estimate against measurement, compound 4: 1.7-fold (0.22 log units) below; low and high end bracket the measured number.
By their numbers in this assay, from the lowest: compound 1; then compounds 4 and 3 (each within the scatter of the next); then compound 2.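

In this assay, phenyl in place of hydrogen on a saturated chain carbon, five bonds along the chain from an aromatic carbon, goes with a 1.5-fold lower number from compound 3 to compound 4 (0.17 log units; within the scatter), so the two compounds cannot be told apart on this read-out. Among the compounds shown here, the one earlier step, a 4.0-fold lower number from compound 2 to compound 3 (0.60 log units; beyond the scatter), showed only that exchanging ethynyl for pentyl on the aromatic carbon can shift the number beyond the scatter; the new pair adds that this chain can carry a further 6 heavy atoms, all carbon and closed into an aromatic ring, at its far end with no shift beyond the scatter. Nothing measured here speaks to the reason for this result.

Still open, going by these compounds, is whether an amine or a carboxylic acid at the far end of the pentyl chain would behave as the phenyl does, or would move the number beyond the scatter. Also open, on these data alone, is how a phenyl on a shorter or a longer chain would read, and whether a fluorine or a methoxy group on that phenyl would change anything.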